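Swapping Furan-2-yl for Methyl on Two Related Cores

This account rests on a few compounds, and the source may have more. Where it says the series, first, only, none or still open, it means among the compounds named here.

Compound 1 `O=C1NN=C(c2ccccc2)/C1=C/Nc1cc(-c2ccco2)[nH]n1` and compound 2 `Cc1cc(N/C=C2\C(=O)NN=C2c2ccccc2)n[nH]1` share a core whose ring nitrogen bears hydrogen, while compound 3 `O=C1/C(=C\Nc2cc(-c3ccco3)[nH]n2)C(c2ccccc2)=NN1c1ccccc1` and compound 4 `Cc1cc(N/C=C2\C(=O)N(c3ccccc3)N=C2c2ccccc2)n[nH]1` carry the core difference (phenyl in place of hydrogen on an amide-type nitrogen in a ring). In a functional assay on MDA-MB-361 cells (Homo sapiens) for antiproliferative activity, read by MTT assay, with a stated time of 72 h (on this read-out higher numbers stand for weaker inhibition and lower numbers for stronger inhibition), compound 1 gives 63700 nM, compound 2 gives 96100 nM, and compound 3 gives 13400 nM. Within the first core the change methyl in place of furan-2-yl on an aromatic carbon produced a 1.5-fold higher number from compound 1 to compound 2 (0.18 log units; within the scatter), whereas the core change produced a 4.8-fold lower number from compound 1 to compound 3 (0.68 log units; beyond the scatter). Compound 4 differs from compound 3 by methyl in place of furan-2-yl on an aromatic carbon, the same change at the same place as that between compound 1 and compound 2. Compound 4 is expected to show a 1.5-fold higher number from compound 3 to compound 4 (0.17 log units; within the scatter) in this assay, because the same change gave a 1.5-fold higher number from compound 1 to compound 2 (0.18 log units; within the scatter) on the other core. Compound 4 is accordingly estimated at 20000 nM, with a likely range from 9000 nM to 45000 nM.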

Compound 4, half-maximal inhibitory concentration: 9980 nM
The estimate for compound 4 lay 2.0-fold (0.30 log units) above the measured number; low and high end bracket the measured number.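

In this assay, methyl in place of furan-2-yl gave a 1.3-fold lower number from compound 3 to compound 4 (0.13 log units; within the scatter), so this change made no readable difference on either core, and the two steps agree: the same change on two cores in this assay, a 1.5-fold higher number (0.18 log units; within the scatter) from compound 1 to compound 2 and a 1.3-fold lower number (0.13 log units; within the scatter) from compound 3 to compound 4, 2.0-fold (0.31 log units) apart, within the scatter of two such steps

Phenyl in place of hydrogen on the amide-type nitrogen gave a 9.6-fold lower number from compound 2 to compound 4 (0.98 log units; beyond the scatter), so this step also carried over, lowering the number with either group on the aromatic carbon: the same change on two cores in this assay, a 4.8-fold lower number (0.68 log units; beyond the scatter) from compound 1 to compound 3 and a 9.6-fold lower number (0.98 log units; beyond the scatter) from compound 2 to compound 4, 2.0-fold (0.31 log units) apart, within the scatter of two such steps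

This shows agreement for only these four compounds; it does not show that the opposite directions of the two methyl steps are real, nor why either change behaves as it does.

From the compounds shown here alone, whether an amine or a carboxylic acid on that aromatic carbon would carry over in the same way remains open. So does the effect of a longer chain in place of phenyl on the amide-type nitrogen.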